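Shrinking the amine ring on a cyclohexyl side chain

The source may report more compounds than this note shows. Statements on the series, on what has been measured and on what is new or still open speak of the compounds shown alone.

Of the compounds shown here, two have been measured so far. In a functional assay on HGC-27 cells (Homo sapiens) for cytotoxicity, read by MTT assay, with a stated time of 24 h (on this read-out lower numbers stand for stronger inhibition and higher numbers for weaker inhibition), compound 1 `C=CC1CN2CCC1CC2[C@@H](Nc1c(Nc2ccc(C(F)(F)F)cc2)c(=O)c1=O)c1ccnc2ccccc12` gives 4530 nM. In this assay compound 2 `O=c1c(Nc2ccc3ccccc3c2-c2c(O)ccc3ccccc23)c(N[C@@H]2CCCC[C@H]2N2CCCCC2)c1=O` gives 11100 nM, the higher of the two numbers, and its gap to compound 1 lies beyond the scatter. Compound 3 `O=c1c(Nc2ccc3ccccc3c2-c2c(O)ccc3ccccc23)c(N[C@@H]2CCCC[C@H]2N2CCCC2)c1=O` differs from compound 2 in one place: pyrrolidin-1-yl in place of piperidin-1-yl on a saturated ring carbon. For the measured compounds named here, no measured pair shows what this swap does, so the expectation rests on compound 2 alone. The expected step from compound 2 to compound 3 is a 1.1-fold lower number from compound 2 to compound 3 (0.05 log units; within the scatter), within the scatter and in no clear direction. Compound 3 is therefore estimated at 10000 nM, ranging from 4000 nM to 25000 nM.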

Compound 3, half-maximal inhibitory concentration: 10800 nM
Compound 3: middle estimate off by 1.1-fold (0.03 log units), on the low side; the measured number falls inside the stated range.
By their numbers in this assay, from the lowest: compound 1; then compounds 3 and 2 (each within the scatter of the next).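

In this assay, pyrrolidin-1-yl in place of piperidin-1-yl on this saturated ring carbon gives a 1.0-fold lower number from compound 2 to compound 3 (0.01 log units; within the scatter) in the cytotoxicity read-out. For the compounds shown here, at this position, then, the smaller ring and the larger ring cannot be told apart, which the earlier compounds could not show. No outside measurement is available to explain this result. Still open, as far as these compounds go, is whether a morpholin-4-yl ring or an open-chain dimethylamino group at this place would shift the number. From the compounds shown here alone, the same swap on a different core also remains untested here.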